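This account rests on a few compounds, and the source may have more. Where it says the series, first, only, none or still open, it means among the compounds named here.

Measured so far in a functional assay on NCI-H460 cells (Homo sapiens) for inhibition, read by CCK-8 assay, with a stated time of 48 h; a higher number here means a weaker inhibitor, a lower number a stronger inhibitor:
compound 1 `Cc1ccc(-c2nn(-c3ccccc3)cc2C(=O)NC(=S)Nc2ccc(Cl)cc2)cc1` gives 3650 nM;
compound 2 `O=C(NC(=S)Nc1ccc(Cl)cc1)c1cn(-c2ccccc2)nc1-c1ccc(F)cc1` gives 3090 nM.

Compound 1 and compound 2 are separated only by a 1.2-fold lower number from compound 1 to compound 2 (0.07 log units; within the scatter), a step within the scatter, so compound 1 stands level with compound 2 in this assay. Compound 3 `Cc1ccc(-c2nn(-c3ccccc3)cc2C(=O)NC(=S)Nc2ccc(F)cc2)cc1` takes from compound 1 the change (fluoro in place of chloro on an aromatic carbon), turning (4-chlorophenyl)amino into (4-fluorophenyl)amino. Within the data shown here, no measured step touches this part of the molecule; the one step in hand, a 1.2-fold lower number from compound 1 to compound 2 (0.07 log units; within the scatter), exchanged fluoro for methyl on the other aryl ring and stayed within the scatter. For compound 3 a step of a 1.0-fold lower number from compound 1 to compound 3 (0.02 log units; within the scatter) is therefore expected, nothing beyond the scatter. Compound 3 is estimated at 3500 nM, range 1800 nM to 7500 nM.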

Compound 3, half-maximal inhibitory concentration: 3980 nM
Estimate against measurement, compound 3: 1.1-fold (0.06 log units) below, within the range that was stated.
By their numbers in this assay, from the lowest: compounds 2, 1 and 3 (each within the scatter of the next).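

In this assay, among these compounds, fluoro in place of chloro on the ring para to a large group gives a 1.1-fold higher number from compound 1 to compound 3 (0.04 log units; within the scatter), the first reading at this position, and this halogen exchange stays within the scatter. No measured evidence accounts for this result. Whether this position responds to anything other than a halogen remains open, as no step shown so far lies beyond the scatter. An amine, a carboxylic acid or a longer chain in place of the chloro of compound 1 would test this.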